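Aryl swap on the triazole nitrogen of the spiro series

This account rests on a few compounds, and the source may have more. Where it says the series, first, only, none or still open, it means among the compounds named here.

Three members of this series have been run in a functional assay on HCT-116 cells (Homo sapiens) for antiproliferative activity, read by MTT assay, with a stated time of 48 h (on this read-out higher numbers stand for weaker inhibition and lower numbers for stronger inhibition), and none has returned a number. Compound 1 `Cc1cccc(-n2nncc2CN2C(=O)C3(C(C#N)=C(N)Oc4c3c3nc5ccccc5nc3c3ccccc43)c3ccccc32)c1` gives > 50000 nM, which is a limit of the assay. Compound 2 `Cc1ccc(Cl)cc1-n1nncc1CN1C(=O)C2(C(C#N)=C(N)Oc3c2c2nc4ccccc4nc2c2ccccc32)c2ccccc21` gives > 50000 nM, again a limit. The step that the two limits leave unreadable from compound 1 to compound 2 therefore cannot be sized. Compound 3 `N#CC1=C(N)Oc2c(N)cc3nc4ccccc4nc3c2C12C(=O)N(Cc1cnnn1-c1ccc(F)cc1)c1ccccc12`, which carries 4-fluorophenyl on the aromatic nitrogen, gives > 50000 nM, also a limit; where compound 3 stands can be said only as this limit, and all three values shown so far sit at the same point, as the limit of > 50000 nM in this assay, at which 3 of the 3 values shown sit, records.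

Compound 4 `COc1ccccc1-n1nncc1CN1C(=O)C2(C(C#N)=C(N)Oc3c(N)cc4nc5ccccc5nc4c32)c2ccccc21` differs from compound 3 by 2-methoxyphenyl in place of 4-fluorophenyl on an aromatic nitrogen. For the measured compounds named here, no measured step bears directly on this change: the single step with neighbouring compounds, from compound 1 to compound 2, is itself unreadable between two limits, and every value in this assay is a limit. There is thus no basis to expect any movement beyond the scatter, and the expectation is that compound 4 will again sit at the limit.

The estimate for compound 4 in this assay is 60000 nM, with a range from 20000 nM to 200000 nM, which corresponds to an expected step that the limit leaves unreadable from compound 3 to compound 4.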

Compound 4, half-maximal inhibitory concentration: > 50000 nM
Compound 4: no number, only a limit (the forecaster's own chance of this, stated with the estimate: 75%); the middle value is on the limit's open side.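

The swap of 4-fluorophenyl for 2-methoxyphenyl gives no readable step between compound 3 and compound 4, as both results are limits of the assay and not numbers: the limit of > 50000 nM in this assay, at which 4 of the 4 values shown sit.

The compounds shown leave open whether any aryl group on that aromatic nitrogen, or any change to the shared core, yields a measurable value in this assay.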